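The source may report more compounds than this note shows. Statements on the series, on what has been measured and on what is new or still open speak of the compounds shown alone.

Three measured compounds frame the question. Compound 1 `CCCCOC(=O)Nc1ccc([Se]C#N)cc1` gives 5000 nM in an ADME assay on BEAS-2B cells (Homo sapiens) for cytotoxicity, read by MTT assay, with a stated time of 72 h; on this read-out higher numbers stand for weaker inhibition of growth and lower numbers for stronger inhibition of growth. Compound 2 `O=C(Nc1ccc([Se][Se]c2ccc(NC(=O)Oc3ccc(F)cc3)cc2)cc1)Oc1ccc(F)cc1` gives 700 nM in this assay, and compound 3 `N#C[Se]c1ccc(NC(=O)Oc2ccc(Cl)cc2)cc1` gives 9300 nM. Among these numbers compound 1 stands second highest: the value of compound 3 lies within the scatter of it, so no order between those two can be read, whereas the value of compound 2 lies beyond the scatter and is the clearly lower number of the set.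

Compound 4 `N#C[Se]c1ccc(NC(=O)OCc2ccccc2)cc1` has not yet been measured. It differs from compound 1 in one place: phenyl in place of propyl on a saturated chain carbon bound to an oxygen next to a carbonyl group. Going by the values given here, no measured pair shows this exact change. Compound 3 gives 9300 nM and sits within the scatter of compound 1, which offers no ground for expecting a large move here. The expected step is no change at the digits printed from compound 1 to compound 4 (within the scatter), none beyond the scatter. Compound 4 is accordingly estimated at 5000 nM, within a range from 2000 nM to 15000 nM.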

Compound 4, concentration for 50% growth inhibition: 100 nM
Estimate against measurement, compound 4: 50-fold (1.70 log units) above; the measured number lies below the stated range.
By their numbers in this assay, from the lowest: compound 4; then compound 2; then compounds 1 and 3 (each within the scatter of the next).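

In this assay, going by these compounds alone, phenyl in place of propyl on a saturated chain carbon bound to an oxygen next to a carbonyl group gives a 50-fold lower number from compound 1 to compound 4 (1.70 log units; beyond the scatter) and so shows that this position, which no earlier pair had tested, responds strongly to the group it carries. Within the data shown here, this is the only one-place change at hand, so it gives the size of the response for this one swap and no trend across groups. The data shown offer no measurement that accounts for the step, and no cause can be given.

The entering phenyl differs from propyl both in its ring and in its count of heavy atoms, so the compounds shown do not separate the two. As far as these compounds go, whether a cyclohexyl group or a longer chain at this place would lower the number in the same way also remains open.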